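The compounds below may be only part of what the source reports. "The series", "measured", "known", "first", "only" and "open" are said of these compounds alone.

Compound 1 `CC[C@@H]1c2cn[nH]c2C(=O)[C@H](CC)N1S(=O)(=O)c1ccc(Cl)cc1` was tested in an ADME assay on microsomes from liver (Homo sapiens) for metabolic stability, using NADPH, with a stated time of 30 min, tested at 1 uM, in the presence of a further agent that is not named here (a higher number here means that more of the compound is left, a lower number that less of the compound is left), where compound 1 gives 10%. That is the lowest of the three numbers measured here. Compound 3 `CCC1c2cn[nH]c2C(=O)CN1S(=O)(=O)c1ccc(C(F)(F)F)cc1` gives 19%, a number within the scatter of compound 1. Compound 2 `CC1(C)C(=O)c2[nH]ncc2C(C2CC2)N1S(=O)(=O)c1ccc(C(F)(F)F)cc1` gives 68%, which stands well beyond the scatter above compound 1. Going by the values given here, compound 4 `CC[C@@H]1C(=O)c2[nH]ncc2[C@H](CC)N1S(=O)(=O)c1ccc(Cl)cc1` has not yet been measured. the two compounds have the same atoms and bonds and differ only in configuration as drawn: 2 of 2 stereo elements differ (all stereocentres are inverted: mirror images); a stereocentre at a saturated ring carbon is drawn S in compound 1 and R in compound 4; a stereocentre at a saturated ring carbon is drawn R in compound 1 and S in compound 4 No measured pair in this set differs only in configuration, so there is no step to draw on. Mirror images are distinct compounds, but nothing here shows the size or direction of such a step, so compound 4 is expected to land near compound 1, with a step of a number 5 percentage points higher from compound 1 to compound 4 (within the scatter) expected to stay within the scatter. Compound 4 is estimated at 15%, between 4% and 40%.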

Compound 4, percent of the compound remaining: 6%
Compound 4: middle estimate off by 9 percentage points, on the high side; the measured number falls inside the stated range.
By their numbers in this assay, from the lowest: compounds 4, 1 and 3 (each within the scatter of the next, the first and the last beyond it); then compound 2.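

In this assay, going by these compounds alone, inverting both stereocentres gives a number 4 percentage points lower from compound 1 to compound 4 (within the scatter), the first step in this set that changes configuration alone. For this mirror-image pair, then, the configuration as drawn has no effect that can be told from the usual scatter. The comparison is a clean one, and it rests on a single fact: the fact that compounds 1 and 4 differ only in the configuration as drawn

Still open, on these data alone, is how a compound with only one of the two stereocentres inverted would compare. Also open, as far as these compounds go, is whether mirror images would stay this close with a carboxylic acid or an amine on the shared core.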